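The source may report more compounds than this note shows. Statements on the series, on what has been measured and on what is new or still open speak of the compounds shown alone.

Compound 1 `COC1CCN(C(=O)N2CC(c3nc(-c4cccc(Cl)c4)no3)C2)CC1` was tested in an assay on HEK293 cells for positive allosteric modulation of metabotropic glutamate receptor 5 (Homo sapiens), read by FLIPR; a higher number here means that more compound is needed for the effect, a lower number that less compound is needed. In this assay compound 1 gives only a limit, > 10000 nM. Compound 2 `Cc1ccc(S(=O)(=O)N2CC(c3nc(-c4cccc(Cl)c4)no3)C2)cc1` was tested the same way. In this assay compound 2 also gives only a limit, > 10000 nM. Where compound 1 stands is therefore fixed only by the limit of > 10000 nM in this assay, at which 2 of the 2 values shown sit. Compound 3 `O=C([C@H]1CC2CCC1C2)N1CC(c2nc(-c3cccc(Cl)c3)no2)C1` has not been measured. It differs from compound 1 in one place: a group of 7 heavy atoms (7 carbon; 2 five-membered non-aromatic rings of carbon only) in place of a group of 8 heavy atoms (6 carbon, 1 nitrogen, 1 oxygen; one six-membered non-aromatic ring with 1 hetero atom), on a carbonyl carbon. Within the data shown here, no measured step between compounds differing in one place exists, so the direction is uncertain. The step of an at least 1.6-fold lower number from compound 1 to compound 3 (0.22 log units; that floor lies within the scatter) is expected to be modest, toward less compound needed. For compound 3 the estimate is 6000 nM, within 1000 nM to 30000 nM.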

Compound 3, half-maximal effective concentration: 74 nM
Compound 3: middle estimate off by 81-fold (1.91 log units), on the high side; measured number outside the range, below it.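

Compound 3 shows that the group on this carbonyl carbon can decide whether any effect is seen in this assay: exchanging 4-methoxypiperidin-1-yl for the all-carbon group with two five-membered rings gives an at least 130-fold lower number from compound 1 to compound 3 (2.13 log units; beyond the scatter). Among these compounds, compound 3 also has the only value shown that is not a limit. The step's true size remains unknown, because it starts from a limit and is only a floor: the limit of > 10000 nM in this assay, at which 2 of the 3 values shown sit.

The compounds shown leave open whether a plain cyclohexyl or tert-butyl group on this carbonyl carbon would serve as well. They also leave open what the defined stereocentre of compound 3 contributes.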